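Swapping a Phenethyl Arm for a Small Amide

A few compounds are considered here, and "the series" means these few. Any claim that something is new, unique, unknown or untested is made for them only; others in the source may bear on it.

Measured compounds:
- compound 1, `CCCCNc1nc(N)nc2cccc(CCc3ccccc3)c12`, 0.47 uM
- compound 2, `CCCCNc1nc(N)nc2cccc(OCc3nccc(OC)c3OC)c12`, > 25 uM

Of the compounds shown here, two sharing one core have been tested in an ADME assay on HEK293 cells for agonist activity at Toll-like receptor 8 (Homo sapiens), read by a luciferase reporter, with a stated time of 6 h; on this read-out higher numbers stand for an effect only at larger amounts of compound and lower numbers for an effect already at smaller amounts. Within the data shown here, compound 1 gives 0.47 uM, the only plain number in this set. Compound 2 gives > 25 uM, which is a limit of this assay and not a number. So compound 1 stands alone as the one compound with a measured concentration, while the other result sits at the limit of > 25 uM in this assay, at which 1 of the 2 values shown sits.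

Compound 3, `CCCCNc1nc(N)nc2cccc(C(=O)N(C)C(C)C)c12`, has not yet been tested. It differs from compound 1 in one place: isopropyl(methyl)carbamoyl in place of phenethyl on an aromatic carbon. Among the measured compounds shown here, no step between two measured compounds exists to show how this assay responds to such a change, so the expectation rests on compound 1 alone and on the size of the change.

The expected step of an 11-fold higher number from compound 1 to compound 3 (1.03 log units; beyond the scatter) is a move toward a larger concentration, beyond the usual scatter. Compound 3 is therefore estimated at 5 uM, with a range from 1 uM to 25 uM.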

Compound 3, minimum effective concentration: > 25 uM
Compound 3 ended at the assay's limit; the forecaster's own chance of this, stated with the estimate: 30%; middle value at least 5.0-fold (0.69 log units) from the limit.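

In this assay, this aromatic carbon now has its first comparison in which only one place differs, and replacing phenethyl with isopropyl(methyl)carbamoyl gives an at least 53-fold higher number from compound 1 to compound 3 (1.72 log units; beyond the scatter), a large step beyond the usual scatter. The swap takes away the six-membered aromatic ring of carbon only and brings in a carbonyl with a hydrogen-bond acceptor and no ring, and the effect seen with compound 1 at low concentration does not carry over to this amide. Compound 3 reaches a limit of the assay and not a number, so the step gives only the smallest possible size of the change: the limit of > 25 uM in this assay, at which 2 of the 3 values shown sit.

The compounds shown leave open which part of the swap matters: losing the aromatic ring, adding the carbonyl, or placing the isopropyl and methyl groups on the amide nitrogen. A benzyl amide or a plain pentyl chain on the same aromatic carbon would help separate these possibilities, one keeping an aromatic ring alongside the amide and the other having neither.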